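Working notes: from pyridin-2-yl to pyridin-4-yl

The source may hold more compounds than are shown below. What is called first, only, known or untested is meant among the compounds shown, and "the series" means these compounds.

compound 1 `CNC(=O)[C@@H]1CCCN1S(=O)(=O)c1ccc(Cl)c(COc2cccc3c(C(F)(F)F)cc(C)nc23)c1Cl`: 1380 mL/min/kg
compound 2 `CNC(=O)[C@@H]1CCCN1S(=O)(=O)c1ccc(Cl)c(COc2cccc3c(-c4nccn4C)cc(C)nc23)c1Cl`: 917 mL/min/kg
compound 3 `CNC(=O)[C@@H]1CCCN1S(=O)(=O)c1ccc(Cl)c(COc2cccc3c(-c4ccccn4)cc(C)nc23)c1Cl`: 733 mL/min/kg

All three compounds were measured in an ADME assay on microsomes (Mus musculus) for metabolic stability; a higher number here means faster removal of the compound, a lower number slower removal. Compound 3 stands at 733 mL/min/kg, and neither of its measured steps leaves the scatter: a 1.9-fold lower number from compound 1 to compound 3 (0.27 log units; within the scatter) and a 1.3-fold lower number from compound 2 to compound 3 (0.10 log units; within the scatter). The next compound is compound 4 `CNC(=O)[C@@H]1CCCN1S(=O)(=O)c1ccc(Cl)c(COc2cccc3c(-c4ccncc4)cc(C)nc23)c1Cl`, with pyridin-4-yl in place of pyridin-2-yl on an aromatic carbon, opposite the ring nitrogen (pyridin-4-yl in place of pyridin-2-yl on an aromatic carbon).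

Among the compounds with values here, no measured step exchanges one pyridinyl group for another, so the evidence is indirect. The closest measured step is the exchange of one aromatic ring for another at this same place: a 1.3-fold lower number from compound 2 to compound 3 (0.10 log units; within the scatter). The replacement of trifluoromethyl by 1-methyl-1H-imidazol-2-yl also stays inside the scatter: a 1.5-fold lower number from compound 1 to compound 2 (0.18 log units; within the scatter). Across these three compounds, no change at this place has gone beyond the scatter, and none goes against that reading.

No step beyond the scatter is therefore expected in this assay, and the data give no direction for it. The expected step is a 1.0-fold higher number from compound 3 to compound 4 (0.01 log units; within the scatter). The estimated value for compound 4 is 750 mL/min/kg, with an expected range from 400 mL/min/kg to 1300 mL/min/kg.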

Compound 4, clearance: 550 mL/min/kg
Estimate against measurement, compound 4: 1.4-fold (0.13 log units) above; measured number inside the range.
By their numbers in this assay, from the lowest: compounds 4, 3, 2 and 1 (each within the scatter of the next, the first and the last beyond it).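

In this assay, moving the ring nitrogen of the pyridine substituent, at this carbon opposite the ring nitrogen of the core, from pyridin-2-yl to pyridin-4-yl does not leave the scatter (a 1.3-fold lower number from compound 3 to compound 4 (0.12 log units; within the scatter)), so the data show no dependence on where that nitrogen sits, for these two isomers. Within the data shown here, the exchange of 1-methyl-1H-imidazol-2-yl for pyridin-4-yl also stays inside the scatter (a 1.7-fold lower number from compound 2 to compound 4 (0.22 log units; within the scatter)), while the replacement of trifluoromethyl by pyridin-4-yl gives the first step beyond the scatter, though a modest one (a 2.5-fold lower number from compound 1 to compound 4 (0.40 log units; beyond the scatter)), and the steps from compound 1 to compound 2 and to compound 3 still lie within it. Nothing measured here accounts for that step.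

Whether pyridin-3-yl would fall with the two pyridine isomers at this position remains open, as does whether a saturated amine such as morpholine or a carboxylic acid here would move the clearance further than any aromatic ring shown. The series also leaves open whether pyridin-4-yl would give a comparable step on a core carrying a change elsewhere, such as at the methyl group.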